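Amide nitrogen substituent: naphthyl to fluorobenzyl

A few compounds are considered here, and "the series" means these few. Any claim that something is new, unique, unknown or untested is made for them only; others in the source may bear on it.

Working notes on the series sharing the core of compound 2. Among the measured compounds shown here, in an assay on isolated protein for inhibition of receptor-type tyrosine-protein phosphatase C (Homo sapiens), read by spectrophotometry (on this read-out higher numbers stand for weaker inhibition and lower numbers for stronger inhibition), compound 2 `O=C(COc1ccc2cc(C(O)(C(F)(F)F)C(F)(F)F)c(O)cc2c1)Nc1cccc2ccccc12` gives 29100 nM, the only number so far. Compound 1 `COc1ccc(CNC(=O)COc2ccc3cc(C(O)(C(F)(F)F)C(F)(F)F)c(O)cc3c2)cc1OC` gives only a limit of this assay at > 20000 nM. For the measured compounds named here, the step that the limit leaves unreadable from compound 1 to compound 2 is the single measured change at the amide-type nitrogen and cannot be sized because the limit of > 20000 nM in this assay, at which 1 of the 2 values shown sits, hides one end of it. Compound 3 `O=C(COc1ccc2cc(C(O)(C(F)(F)F)C(F)(F)F)c(O)cc2c1)NCc1ccc(F)cc1` has yet to be measured; the change from compound 2 is 4-fluorobenzyl in place of naphthalen-1-yl on an amide-type nitrogen. Going by the values given here, the only precedent at this position is unreadable, so no direction can be taken from the data; what is seen is that the benzyl-type amide of compound 1 sits at the limit while the naphthyl amide of compound 2 is close to that limit. Compound 3 is therefore expected to stay in this weak region, with a step of a 1.0-fold higher number from compound 2 to compound 3 (0.01 log units; within the scatter) that is expected to be no larger than the scatter. Compound 3 is estimated at 30000 nM, with a range from 10000 nM to 90000 nM, and a limit is expected to be a likely outcome.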

Compound 3, half-maximal inhibitory concentration: > 20000 nM
Compound 3: only a limit was reported; the forecaster's own chance of this, stated with the estimate: 50%; the middle value does not contradict the limit.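

In this assay compound 3 gives > 20000 nM, which is a limit and not a number, so neither step to it, from compound 1 or from compound 2, can be read: the limit of > 20000 nM in this assay, at which 2 of the 3 values shown sit.

The compounds shown leave open whether 4-fluorobenzyl and naphthalen-1-yl on the amide-type nitrogen differ at all in inhibition.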